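The source may hold more compounds than are shown below. What is called first, only, known or untested is meant among the compounds shown, and "the series" means these compounds.

Compound 1 `Nc1ncnc2c1c(-c1cnc3[nH]ccc3c1)nn2CCCCCCC(=O)NO` and compound 2 `Nc1nc2cc(-c3nn(CCCCC(=O)NO)c4ncnc(N)c34)ccc2o1` were both tested in a functional assay on HeLa cells (Homo sapiens) for inhibition, read by MTT assay, with a stated time of 72 h; on this read-out lower numbers stand for stronger inhibition and higher numbers for weaker inhibition. In this assay compound 1 gives 22000 nM, and compound 2 gives 32200 nM; the gap between the two numbers lies within the scatter, so neither can be set apart from the other. Compound 3 `CNC(=O)CCCCCCCn1nc(-c2cnc3[nH]ccc3c2)c2c(N)ncnc21` has not yet been measured. It differs from compound 1 in one place: (methylcarbamoyl)methyl in place of hydroxycarbamoyl on a saturated chain carbon, six bonds along the chain from an aromatic nitrogen. Going by the values given here, no measured pair shows this change. Compound 3 is expected to show weaker inhibition, with a step of a 3.0-fold higher number from compound 1 to compound 3 (0.47 log units; beyond the scatter) expected to reach beyond the scatter. The estimated value of compound 3 is 65000 nM, with a range from 20000 nM to 200000 nM.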

Compound 3, half-maximal inhibitory concentration: 29100 nM
Compound 3: the middle estimate sits 2.2-fold (0.35 log units) above what was measured; the measured number falls inside the stated range.
By their numbers in this assay, from the lowest: compounds 1, 3 and 2 (each within the scatter of the next).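

Putting (methylcarbamoyl)methyl in place of hydroxycarbamoyl on a saturated chain carbon, six bonds along the chain from an aromatic nitrogen, gives a 1.3-fold higher number from compound 1 to compound 3 (0.12 log units; within the scatter) in this assay. The earlier compounds shown here offered no such pair; this one shows that, on the core of compound 1, the hydroxycarbamoyl group can be exchanged at this position without a step that stands clear of the scatter. No measurement at hand bears on this result.

From the compounds shown here alone, whether a carboxylic acid or an amine at this position would read the same remains open. So does the effect of a shorter or longer chain carrying hydroxycarbamoyl on this core.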